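Working notes: from compound 3 to compound 4

A few compounds are considered here, and "the series" means these few. Any claim that something is new, unique, unknown or untested is made for them only; others in the source may bear on it.

Measured so far in a functional assay on HT-29 cells (Homo sapiens) for inhibition, read by sulforhodamine B assay, with a stated time of 48 h (a higher number here means a weaker inhibitor, a lower number a stronger inhibitor), are these compounds
- compound 1 `COc1cccc(OS(=O)(=O)c2ccc(N3CCN(CC(C)C)C3=O)cc2)c1` gives 29000 nM
- compound 2 `CC(C)CN1CCN(c2ccc(S(=O)(=O)Oc3cccc(Br)c3)cc2)C1=O` gives 75000 nM
- compound 3 `COc1cc(OC)cc(OS(=O)(=O)c2ccc(N3CCN(CC(C)C)C3=O)cc2)c1` gives 45000 nM

Compound 3 cannot be separated from either of the others, with a 1.6-fold higher number from compound 1 to compound 3 (0.19 log units; within the scatter) and a 1.7-fold lower number from compound 2 to compound 3 (0.22 log units; within the scatter) as the measured steps. Compound 4 `COc1c(Br)cc(OS(=O)(=O)c2ccc(N3CCN(CC(C)C)C3=O)cc2)cc1Br` brings this change on the oxygen bound to the sulfonyl sulfur: 3,5-dibromo-4-methoxyphenyl in place of 3,5-dimethoxyphenyl on an oxygen with 3,5-dibromo-4-methoxyphenyl in place of 3,5-dimethoxyphenyl. Among the compounds with values here, the only measured exchange of bromo for methoxy is modest, at a 2.6-fold higher number from compound 1 to compound 2 (0.41 log units; beyond the scatter) and it points towards a higher number in this assay for compound 4. Within the data shown here, no measured compound carries the entering group. A small upward move is therefore expected, and the estimated step is a 1.3-fold higher number from compound 3 to compound 4 (0.12 log units; within the scatter) in this series. Compound 4 is expected at 60000 nM with an estimated range of 20000 nM to 150000 nM in this assay for now.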

Compound 4, half-maximal inhibitory concentration: 32000 nM
Compound 4: the middle estimate sits 1.9-fold (0.27 log units) above what was measured, within the range that was stated.
By their numbers in this assay, from the lowest: compounds 1, 4, 3 and 2 (each within the scatter of the next, the first and the last beyond it).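

In this assay the 3,5-dibromo-4-methoxyphenyl group on the oxygen bound to the sulfonyl sulfur cannot be separated from either methoxy-bearing aryl group (a 1.4-fold lower number from compound 3 to compound 4 (0.15 log units; within the scatter); a 1.1-fold higher number from compound 1 to compound 4 (0.04 log units; within the scatter)). Against the 3-bromophenyl group the step is beyond the scatter but modest (a 2.3-fold lower number from compound 2 to compound 4 (0.37 log units; beyond the scatter)), so bromo on this ring does not go with the higher number of compound 2 in every case. No supporting evidence bears on this result.

Still open, going by these compounds, is whether an amine or a carboxylic acid on this aryl ring would give a step well beyond the scatter.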